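Swapping piperidin-4-yl for pyridin-3-yl on the shared core

A few compounds are considered here, and "the series" means these few. Any claim that something is new, unique, unknown or untested is made for them only; others in the source may bear on it.

Within the data shown here, in a functional assay on MCF7 cells (Homo sapiens) for antiproliferative activity, read by MTT assay, with a stated time of 24 h (on this read-out higher numbers stand for weaker inhibition and lower numbers for stronger inhibition), compound 2 `COc1ccc(-c2noc(C3CCNCC3)n2)cc1OC1CCCC1` gives 3880 nM, the only true number so far. Compound 1 `COc1ccc(-c2noc(-c3ccncc3)n2)cc1OC1CCCC1` reaches only a limit, > 1000000 nM. Compound 3 `COc1cc(-c2noc(-c3ccncc3)n2)ccc1OCc1ccccc1` likewise reaches only a limit, > 1000000 nM. Compound 4 `COc1ccc(-c2noc(-c3cccnc3)n2)cc1OC1CCCC1` carries pyridin-3-yl in place of piperidin-4-yl on an aromatic carbon, so an aromatic ring with one ring nitrogen returns at that place. Among the measured compounds shown here, the one measured step that bears on this is an at least 250-fold lower number from compound 1 to compound 2 (2.41 log units; beyond the scatter), a large gain that came with pyridin-4-yl leaving. Pyridin-3-yl is a different group, but a large step back towards weaker inhibition is expected. The expected change is a 77-fold higher number from compound 2 to compound 4 (1.89 log units; beyond the scatter). Compound 4 is estimated at 300000 nM, with a range of 30000 nM to 1000000 nM.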

Compound 4, half-maximal inhibitory concentration: > 1000000 nM
Compound 4 gave a limit, no number; the forecaster's own chance of this, stated with the estimate: 55%; middle value at least 3.3-fold (0.52 log units) from the limit.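

In this assay, an aromatic ring at this place again loses the activity, with an at least 250-fold higher number from compound 2 to compound 4 (2.41 log units; beyond the scatter), so the loss is not tied to pyridin-4-yl alone. Of the three groups shown here, only piperidin-4-yl gives a true number. The step between the two pyridine compounds, compound 1 and compound 4, cannot be read, because both values are limits: the limit of > 1000000 nM in this assay, at which 3 of the 4 values shown sit.

Going by these compounds, what matters in piperidin-4-yl, the non-aromatic ring or the hydrogen on its nitrogen, stays open. A cyclohexyl group, or a piperidin-4-yl with a methyl on its ring nitrogen, would help separate the two.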